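The source may report more compounds than this note shows. Statements on the series, on what has been measured and on what is new or still open speak of the compounds shown alone.

In a functional assay on A549 cells (Homo sapiens) for antiproliferative activity, read by MTT assay, with a stated time of 48 h (a lower number here means a stronger inhibitor, a higher number a weaker inhibitor), compound 1 `CCCC(C)Oc1ccc(C(=O)/C=C/c2c(/C=C/c3ccc(OC)cc3)cc(OC)cc2OC)cc1` gives 9.4 ug/mL and compound 2 `CCCCOc1ccc(C(=O)/C=C/c2c(/C=C/c3ccc(OC)cc3)cc(OC)cc2OC)cc1` gives 8.7 ug/mL while compound 3 `CCOc1ccc(C(=O)/C=C/c2c(/C=C/c3ccc(OC)cc3)cc(OC)cc2OC)cc1` gives 7.5 ug/mL and so stands within the scatter of both others. Compound 4 `COc1ccc(/C=C/c2cc(OC)cc(OC)c2/C=C/C(=O)c2ccc(-c3ccccc3)cc2)cc1` has not yet been measured. It carries phenyl in place of ethoxy on an aromatic carbon and so turns the 4-ethoxyphenyl into a 4-phenylphenyl. Going by the values given here, the steps that bear on this are all changes in the alkoxy chain, and each of them stayed within the scatter: a 1.1-fold lower number from compound 1 to compound 2 (0.03 log units; within the scatter) and a 1.2-fold lower number from compound 2 to compound 3 (0.06 log units; within the scatter) and also a 1.3-fold lower number from compound 1 to compound 3 (0.10 log units; within the scatter) in the same measurements. None of them removes the oxygen or puts a ring in its place, so they guide this change only loosely. With compound 3 at 7.5 ug/mL as the starting point, no step beyond the scatter is expected in this assay although the range must stay wide. The expected change is a 1.2-fold higher number from compound 3 to compound 4 (0.08 log units; within the scatter) and rests on little direct evidence. Compound 4 is estimated at 9 ug/mL with an expected range from 4.5 ug/mL to 18 ug/mL.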

Compound 4, half-maximal inhibitory concentration: 4.6 ug/mL
Compound 4: the middle estimate sits 2.0-fold (0.29 log units) above what was measured; the measured number falls inside the stated range.
By their numbers in this assay, from the lowest: compounds 4, 3, 2 and 1 (each within the scatter of the next, the first and the last beyond it).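

The alkoxy chains had shown only that the ether's alkyl part could vary, whereas compound 4 shows that in this assay the whole ether, oxygen included, can give way to a six-membered aromatic ring on this aromatic carbon without the number leaving the scatter of the ethoxy or butoxy compounds (a 1.6-fold lower number from compound 3 to compound 4 (0.21 log units; within the scatter); a 1.9-fold lower number from compound 2 to compound 4 (0.28 log units; within the scatter)). Going by these compounds alone, only against the 1-methylbutoxy compound does the replacement pass the scatter, and then modestly (a 2.0-fold lower number from compound 1 to compound 4 (0.31 log units; beyond the scatter)), the one step in this set to do so. Nothing measured here accounts for this result.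

Phenoxy, which would keep the oxygen and add the ring, would help to separate the two parts of this change. Also open, from the compounds shown here alone, is how an amine, a carboxylic acid or a cyclohexyl ring would read on this carbon, and whether groups on the added phenyl would move the number.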